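Quinone for hydroquinone on a pyrazole series

The compounds below may be only part of what the source reports. "The series", "measured", "known", "first", "only" and "open" are said of these compounds alone.

Measured compounds:
compound 1 `NS(=O)(=O)c1ccc(-n2nc(-c3ccc(Cl)cc3)cc2-c2cc(O)ccc2O)cc1`: 50900 nM
compound 2 `CC(=O)NS(=O)(=O)c1ccc(-n2nc(-c3ccccc3)cc2-c2cc(O)ccc2O)cc1`: 100000 nM
compound 3 `NS(=O)(=O)c1ccc(-n2nc(-c3ccc(Cl)cc3)cc2C2=CC(=O)C=CC2=O)cc1`: 65700 nM

In a functional assay on cells (Cancer cell lines, Homo sapiens) for cytotoxicity, read by sulforhodamine B assay, with a stated time of 48 h (on this read-out lower numbers stand for stronger inhibition of growth and higher numbers for weaker inhibition of growth), compound 1 gives 50900 nM, and compound 3 gives 65700 nM. The change between them is a group of 8 heavy atoms (6 carbon, 2 oxygen; one six-membered non-aromatic ring of carbon only) in place of a group of 8 heavy atoms (6 carbon, 2 oxygen; one six-membered aromatic ring of carbon only), on an aromatic carbon and the step is a 1.3-fold higher number from compound 1 to compound 3 (0.11 log units; within the scatter). Compound 2 gives 100000 nM in this assay; the difference between the core of compound 2 and the core of compound 1 is not broken down here.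

Compound 4 `CC(=O)NS(=O)(=O)c1ccc(-n2nc(-c3ccccc3)cc2C2=CC(=O)C=CC2=O)cc1` has not yet been measured. It differs from compound 2 by a group of 8 heavy atoms (6 carbon, 2 oxygen; one six-membered non-aromatic ring of carbon only) in place of a group of 8 heavy atoms (6 carbon, 2 oxygen; one six-membered aromatic ring of carbon only), on an aromatic carbon. This is the same kind of change as from compound 1 to compound 3, but the surroundings differ: in compound 2 the place is next to the ring atom that bears a large group and two ring bonds from the ring atom that bears a phenyl group, while in compound 1 it is next to the ring atom that bears a 4-sulfamoylphenyl group and two ring bonds from the ring atom that bears a 4-chlorophenyl group.

Among the measured compounds shown here, the expected step for compound 4 in this assay is a 1.2-fold higher number from compound 2 to compound 4 (0.08 log units; within the scatter), because the only measured example of this change is a 1.3-fold higher number from compound 1 to compound 3 (0.11 log units; within the scatter), which lies within the scatter. For compound 4 the estimate is 120000 nM, with a range from 60000 nM to 250000 nM.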

Compound 4, concentration for total growth inhibition: 100000 nM
Estimate against measurement, compound 4: 1.2-fold (0.08 log units) above; the measured number falls inside the stated range.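

In this assay, the quinone ring in place of the 2,5-dihydroxyphenyl group gives no change at the digits printed from compound 2 to compound 4 (within the scatter), so this core also shows no step beyond the scatter. The change carries across the two cores without a detectable difference between its steps: the same change on two cores in this assay, a 1.3-fold higher number (0.11 log units; within the scatter) from compound 1 to compound 3 and no change at the digits printed (within the scatter) from compound 2 to compound 4, 1.3-fold (0.11 log units) apart, within the scatter of two such steps. Among the compounds shown here, this covers only two cores, both with high numbers on this read-out, and it does not show that the change would stay silent on a core with a much lower number, nor does a flat step show that the two groups behave alike outside this assay.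

Going by these compounds, the cores of compound 1 and compound 2 differ in both the 4-chlorophenyl or phenyl group and the acetyl on the sulfonamide, so the separate contribution of each remains open. Also open, on these data alone, is whether a 2,5-dimethoxyphenyl group in the same place, or a carboxylic acid in place of the sulfonamide, would move the number at all.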